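The source may hold more compounds than are shown below. What is called first, only, known or untested is meant among the compounds shown, and "the series" means these compounds.

Compounds measured so far: compound 1 `CCn1c(C(=O)NCC(OC)OC)ccc1C(CC)(CC)c1ccc(OCC(O)C(C)(C)C)c(C)c1` with 150 nM in an assay on HL-60 cells for agonist activity at vitamin D3 receptor (Homo sapiens), read by microscopy, with a stated time of 96 h (on this read-out higher numbers stand for an effect only at larger amounts of compound and lower numbers for an effect already at smaller amounts), and compound 2 `CCn1c(C(=O)N(C)CC(=O)O)ccc1C(CC)(CC)c1ccc(OCC(O)C(C)(C)C)c(C)c1` with 740 nM in this assay.

For the measured compounds named here, compound 2 stands at the higher of the two numbers; its only neighbour is compound 1, and the step of a 4.9-fold higher number from compound 1 to compound 2 (0.69 log units; beyond the scatter) separates them. Compound 3 `CCn1c(C(=O)Nc2ccc(OC(F)(F)F)cc2)ccc1C(CC)(CC)c1ccc(OCC(O)C(C)(C)C)c(C)c1` has not yet been tested in this assay. It differs from compound 2 by (4-(trifluoromethoxy)phenyl)amino in place of (carboxymethyl)(methyl)amino on a carbonyl carbon. Going by the values given here, the one measured step that bears on this change is a 4.9-fold higher number from compound 1 to compound 2 (0.69 log units; beyond the scatter), which shows that exchanging the group on the carbonyl carbon moves the number by a modest amount. Compound 3, like compound 1, carries a single hydrogen-bond donor on the amide, so a return towards the number of compound 1 is expected, and the step of a 3.7-fold lower number from compound 2 to compound 3 (0.57 log units; beyond the scatter) is estimated to be modest and downward. Compound 3 is therefore expected to give about 200 nM, within a range from 50 nM to 800 nM.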

Compound 3, half-maximal effective concentration: > 50000 nM
Compound 3: a limit, no number (the forecaster's own chance of this, stated with the estimate: 5%); middle value at least 250-fold (2.39 log units) away from the limit.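

In this assay the value of compound 3 is a limit of the assay and not a number: the limit of > 50000 nM in this assay, at which 1 of the 3 values shown sits. Changing the group on the carbonyl carbon need not be a modest matter, as the earlier 4.9-fold higher number from compound 1 to compound 2 (0.69 log units; beyond the scatter) might have suggested: the (4-(trifluoromethoxy)phenyl)amino group gives an at least 67-fold higher number from compound 2 to compound 3 (1.82 log units; beyond the scatter), a large step. The amide hydrogen shared by compound 1 and compound 3 does not by itself hold the number near that of compound 1, as the other large step shows, an at least 330-fold higher number from compound 1 to compound 3 (2.52 log units; beyond the scatter).

The compounds shown leave open whether the aromatic ring or the trifluoromethoxy group on it goes with this rise. An unsubstituted phenyl or a benzyl on the same nitrogen would separate the two.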